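A few compounds are considered here, and "the series" means these few. Any claim that something is new, unique, unknown or untested is made for them only; others in the source may bear on it.

Three compounds share one core and carry a fully acetylated sugar attached through an oxygen. Compound 1 `CC(=O)OC[C@H]1O[C@@H](OC2=CC(=O)c3ccccc3C2=O)[C@H](OC(C)=O)[C@@H](OC(C)=O)[C@@H]1OC(C)=O` and compound 2 `CC(=O)OC[C@H]1O[C@H](OC2=CC(=O)c3ccccc3C2=O)[C@H](OC(C)=O)[C@@H](OC(C)=O)[C@@H]1OC(C)=O` have the same atoms and bonds and differ only in configuration as drawn. In a functional assay on MDA-MB-231 cells (Homo sapiens) for cytotoxicity, read by sulforhodamine B assay, with a stated time of 72 h (on this read-out lower numbers stand for stronger inhibition and higher numbers for weaker inhibition), compound 1 gives 12600 nM, while compound 2 gives 8290 nM; the step is a 1.5-fold lower number from compound 1 to compound 2 (0.18 log units; within the scatter), and the fact that compounds 1 and 2 differ only in the configuration as drawn is all that separates them. Compound 3 `CC(=O)N[C@H]1[C@@H](OC2=CC(=O)c3ccccc3C2=O)O[C@H](COC(C)=O)[C@@H](OC(C)=O)[C@@H]1OC(C)=O` carries an acetamido in place of acetoxy on a saturated ring carbon; in this assay compound 3 gives 19800 nM, which is a 2.4-fold higher number from compound 2 to compound 3 (0.38 log units; beyond the scatter). Among the three numbers, compound 3 stands highest, close to compound 1 and furthest from compound 2.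

Compound 4 `CC(=O)N[C@H]1[C@H](OC2=CC(=O)c3ccccc3C2=O)O[C@H](COC(C)=O)[C@@H](OC(C)=O)[C@@H]1OC(C)=O` follows from compound 3 by a change of configuration alone: the two compounds have the same atoms and bonds and differ only in configuration as drawn: 1 of 5 stereo elements differ; a stereocentre at a saturated ring carbon is drawn R in compound 3 and S in compound 4. For the measured compounds named here, the only measured step of the same kind is the one from compound 1 to compound 2, a drawn inversion at a ring carbon that stayed within the scatter. On that basis a step within the scatter is expected in this assay, with no clear direction. Compound 4 is therefore estimated at 15000 nM, between 7000 nM and 35000 nM, which corresponds to an expected step of a 1.3-fold lower number from compound 3 to compound 4 (0.12 log units; within the scatter).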

Compound 4, half-maximal inhibitory concentration: 27600 nM
Compound 4: the middle estimate sits 1.8-fold (0.26 log units) below what was measured; measured number inside the range.
By their numbers in this assay, from the lowest: compounds 2, 1, 3 and 4 (each within the scatter of the next, the first and the last beyond it).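

With a 1.4-fold higher number from compound 3 to compound 4 (0.14 log units; within the scatter), the drawn inversion at this saturated ring carbon again leaves no readable difference, so in this assay the same holds with acetamido on the sugar as with acetoxy, and the drawn configuration here does not separate the compounds on either sugar: the fact that compounds 3 and 4 differ only in the configuration as drawn

The swap of acetoxy for acetamido, until now seen only once, has a second case in a 2.2-fold higher number from compound 1 to compound 4 (0.34 log units; beyond the scatter), and it is modest but beyond the scatter, just as the first one was: the same change on two cores in this assay, a 2.4-fold higher number (0.38 log units; beyond the scatter) from compound 2 to compound 3 and a 2.2-fold higher number (0.34 log units; beyond the scatter) from compound 1 to compound 4, 1.1-fold (0.04 log units) apart, within the scatter of two such steps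

Taken together, the four compounds form a small square in which changing the configuration gives no readable step on either sugar, while changing acetoxy to acetamido gives a step of nearly the same size in both configurations.

The compounds shown hold only acetoxy or acetamido at this ring carbon, so how a free hydroxyl, a free amine or a longer acyl chain such as butanamido would read there remains open. As far as these compounds go, it is also open whether the same pattern would hold on a sugar whose other acetoxy groups are replaced by free hydroxyls, or on a different core.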